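Trimethoxyphenyl triazoles: an ethoxy step from compound 3

The source may hold more compounds than are shown below. What is called first, only, known or untested is meant among the compounds shown, and "the series" means these compounds.

Compound 1 `COc1cc(-n2ncnc2-c2ccc(F)cc2)cc(OC)c1OC`, compound 2 `COc1cc(-n2ncnc2-c2ccccc2)cc(OC)c1OC` and compound 3 `COc1cc(-n2ncnc2-c2cccc(Cl)c2)cc(OC)c1OC` share the same core and differ only on the pendant phenyl ring. In a functional assay on HL-60 cells (Homo sapiens) for antiproliferative activity, read by MTT assay, with a stated time of 72 h (a lower number here means a stronger inhibitor, a higher number a weaker inhibitor), compound 1 gives > 10000 nM, which is a limit of the assay rather than a number. In this assay compound 2 likewise gives > 10000 nM, again a limit. Compound 3 gives > 10000 nM, also a limit. All three therefore stand at the same place, (the limit of > 10000 nM in this assay, at which 3 of the 3 values shown sit), and none is separable from the others. The steps a step that the two limits leave unreadable from compound 1 to compound 2, a step that the two limits leave unreadable from compound 1 to compound 3 and a step that the two limits leave unreadable from compound 2 to compound 3 carry no readable size for that reason.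

Compound 4 `CCOc1ccc(-c2ncnn2-c2cc(OC)c(OC)c(OC)c2)cc1Cl` differs from compound 3 by ethoxy in place of hydrogen on an aromatic carbon. Within the data shown here, no measured step bears on an ethoxy group; the only changes seen so far were swaps of small halogens or hydrogen, and all of those stayed at the limit. The expectation for compound 4 in this assay is therefore weak activity, with the step of an at least 1.2-fold lower number from compound 3 to compound 4 (0.09 log units; that floor lies within the scatter) expected to be small and its direction open. Compound 4 is estimated at 8000 nM, with a range from 1000 nM to 30000 nM.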

Compound 4, half-maximal inhibitory concentration: 3 nM
The estimate for compound 4 lay 2700-fold (3.43 log units) above the measured number; measured number below the stated range.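

Working notes: this aromatic carbon, ortho to a chloro group and para to a large group, is the first place in the series where a change can be read in this assay. Ethoxy in place of hydrogen there gives an at least 3300-fold lower number from compound 3 to compound 4 (3.52 log units; beyond the scatter), so the position responds strongly to this substituent, whereas the swaps among compound 1, compound 2 and compound 3 cannot be read. Compound 4 is the only compound shown with a measured number rather than a limit: the limit of > 10000 nM in this assay, at which 3 of the 4 values shown sit.

The compounds shown do not tell whether the ethoxy group acts alone or needs the chloro group ortho to it. From the compounds shown here alone, how a methoxy group, a longer propoxy chain or an amine at the same carbon would read in this assay also stays open.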